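Hydroxy-to-fluoro exchange on the acetyl-bearing ring

A few compounds are considered here, and "the series" means these few. Any claim that something is new, unique, unknown or untested is made for them only; others in the source may bear on it.

Two compounds carry a measurement in an assay on isolated protein for inhibition of Amine oxidase [flavin-containing] B (Homo sapiens), read by fluorescence, with a stated time of 15 min (on this read-out lower numbers stand for stronger inhibition and higher numbers for weaker inhibition), so far. Compound 1 `CC(=O)c1ccc(OCc2cccc(F)c2)cc1O` gives 41.4 nM in this assay, the higher of the two numbers. Compound 2 `O=C1OCc2cc(OCc3ccc(F)cc3)ccc21` gives 8.35 nM in this assay, a gap from compound 1 that lies beyond the usual scatter. Compound 2 differs from compound 1 in more than one place, so the two values alone carry no single-change reading.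

Compound 3 `CC(=O)c1ccc(OCc2cccc(F)c2)cc1F` is not yet measured in this assay. It differs from compound 1 in one place: fluoro in place of hydroxy on an aromatic carbon. Within the data shown here, no measured pair shows this change, and nothing here tells which way it moves the number. A modest step is expected, from compound 1 to compound 3, of a 1.9-fold higher number from compound 1 to compound 3 (0.29 log units; within the scatter), with a weaker number somewhat more likely than a stronger one. Compound 3 is expected to come in at 80 nM, within 20 nM to 400 nM.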

Compound 3, half-maximal inhibitory concentration: 96.5 nM
Beside the measured number, compound 3's estimate is 1.2-fold (0.08 log units) below it; the range from low to high includes it.
By their numbers in this assay, from the lowest: compound 2; then compound 1; then compound 3.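

In this assay, among these compounds, this is the first single-change reading: on the aromatic carbon ortho to an acetyl group, fluoro in place of hydroxy gives a 2.3-fold higher number from compound 1 to compound 3 (0.37 log units; beyond the scatter). The position therefore responds to this exchange, but the step is modest, and activity stays in the same range even though the hydrogen-bond donor and acceptor counted for hydroxy are gone and fluoro brings neither. Nothing measured on hand accounts for the step.

The compounds shown leave open how an amine or a methoxy group on this carbon would compare with hydroxy and fluoro. They also leave open whether the step keeps its direction and size on another core, such as that of compound 2, which differs from compound 1 in more than one place.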